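Chlorine in place of fluorine on the indazole

The source may hold more compounds than are shown below. What is called first, only, known or untested is meant among the compounds shown, and "the series" means these compounds.

In a functional assay on MCF7 cells (Homo sapiens) for cytotoxicity, read by CellTiter-Glo, with a stated time of 5 days (on this read-out lower numbers stand for stronger inhibition and higher numbers for weaker inhibition), compound 2 `CC/C(=C(/c1ccc(/C=C/C(=O)O)cc1)c1ccc2[nH]ncc2c1F)c1ccccc1` gives 3 nM. Compound 3 `CC/C(=C(/c1ccc(/C=C/C(=O)O)cc1)c1cc(F)c2[nH]ncc2c1)c1ccccc1` gives 7.5 nM in this assay and stands highest of the two numbers there, with compound 2 nearest: a 2.5-fold higher number from compound 2 to compound 3 (0.40 log units; beyond the scatter). Compound 1 `CC/C(=C(/c1ccc(/C=C/C(=O)O)cc1)c1ccc2[nH]nc(C)c2c1)c1ccccc1` reaches only a limit in this assay, > 1000 nM, which is a limit of the assay and not a number (the limit of > 1000 nM in this assay, at which 1 of the 3 values shown sits). The steps from it are large: an at least 330-fold lower number from compound 1 to compound 2 (2.52 log units; beyond the scatter) and an at least 130-fold lower number from compound 1 to compound 3 (2.12 log units; beyond the scatter).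

Compound 4 `CC/C(=C(/c1ccc(/C=C/C(=O)O)cc1)c1ccc2[nH]ncc2c1Cl)c1ccccc1` differs from compound 3 in one place: 4-chloro-1H-indazol-5-yl in place of 7-fluoro-1H-indazol-5-yl on a double-bonded chain carbon bound to an aromatic carbon and a double-bonded chain carbon. For the measured compounds named here, no measured step exchanges fluorine for chlorine. The step that bears most on it is the one between the two fluoro compounds, a 2.5-fold higher number from compound 2 to compound 3 (0.40 log units; beyond the scatter), a modest one, while the steps from compound 1 show that the indazole substituent can move the number a long way. A modest step toward a lower number in this assay is therefore expected, roughly to where compound 2 stands. Compound 4 is expected at 4 nM, between 1.5 nM and 12 nM. The expected step is a 1.9-fold lower number from compound 3 to compound 4 (0.27 log units; within the scatter).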

Compound 4, half-maximal inhibitory concentration: 1.6 nM
The estimate for compound 4 lay 2.5-fold (0.40 log units) above the measured number; measured number inside the range.
By their numbers in this assay, from the lowest: compounds 4 and 2 (each within the scatter of the next); then compound 3. At a limit, above all of these: compound 1.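

With chloro in place of fluoro on an aromatic carbon, the number shows a 1.9-fold lower number from compound 2 to compound 4 (0.27 log units; within the scatter), so in this assay the 4-chloro-1H-indazol-5-yl and 4-fluoro-1H-indazol-5-yl groups cannot be told apart. Against 7-fluoro-1H-indazol-5-yl, the change to 4-chloro-1H-indazol-5-yl gives a 4.7-fold lower number from compound 3 to compound 4 (0.67 log units; beyond the scatter), so both 4-halo compounds now stand apart from compound 3 in this assay. The step from 3-methyl-1H-indazol-5-yl is an at least 620-fold lower number from compound 1 to compound 4 (2.79 log units; beyond the scatter), but it starts from a limit of the assay and not a number: the limit of > 1000 nM in this assay, at which 1 of the 4 values shown sits.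

The compounds shown leave open how a bromo, methoxy or nitrile group would stand in place of the chloro of 4-chloro-1H-indazol-5-yl. They also leave open where the unsubstituted 1H-indazol-5-yl group would fall, so the shares of the halogens and of the methyl group remain unseparated.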